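Sulfonylacetic acid ethers: terminal aryl group exchange, notes

This account rests on a few compounds, and the source may have more. Where it says the series, first, only, none or still open, it means among the compounds named here.

Measured so far:
compound 1 `COc1ccccc1-c1cccc(COc2ccc(S(=O)(=O)CC(=O)O)cc2)c1` – 195 nM
compound 2 `O=C(O)CS(=O)(=O)c1ccc(OCc2cccc(Oc3ccccc3)c2)cc1` – 97.7 nM

In a functional assay on CHO cells for agonist activity at Free fatty acid receptor 1 (Homo sapiens), read by FLIPR and calcium flux (a lower number here means that less compound is needed, a higher number that more compound is needed for the effect), compound 1 gives 195 nM. In this assay compound 2 gives 97.7 nM, the lower of the two numbers. For the measured compounds named here, the single measured step, a 2.0-fold lower number from compound 1 to compound 2 (0.30 log units; within the scatter), lies within the scatter, so compound 2 and compound 1 are not separated by the data.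

Compound 3 `Cc1noc(C)c1-c1cccc(COc2ccc(S(=O)(=O)CC(=O)O)cc2)c1` has not been measured. Its change relative to compound 2 is 3,5-dimethyl-1,2-oxazol-4-yl in place of phenoxy on an aromatic carbon. Going by the values given here, no measured step involves a five-membered aromatic ring at this position; the only step available exchanged one six-membered aromatic substituent for another and gave a 2.0-fold lower number from compound 1 to compound 2 (0.30 log units; within the scatter), within the scatter. That one step is the whole basis for expectation, and it shows no movement beyond the scatter for an exchange of the terminal group at this place.

For compound 3 in this assay the estimate is therefore 150 nM, with a range from 40 nM to 600 nM. From the compounds shown here alone, the step this expectation implies, a 1.5-fold higher number from compound 2 to compound 3 (0.19 log units; within the scatter), is expected to stay within the scatter, with the wider range reflecting that a five-membered ring with two hetero atoms is untested here.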

Compound 3, half-maximal effective concentration: 269 nM
Beside the measured number, compound 3's estimate is 1.8-fold (0.25 log units) below it, and the stated range covers the measured number.
By their numbers in this assay, from the lowest: compounds 2, 1 and 3 (each within the scatter of the next, the first and the last beyond it).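

Notes on the exchange: in this assay the step of a 2.8-fold higher number from compound 2 to compound 3 (0.44 log units; beyond the scatter) is the first one in this short series to lie beyond the scatter, modest as it is, and it shows that the terminal group on this aromatic carbon, meta to a large group, is not wholly indifferent to exchange, even with the heavy-atom count unchanged between phenoxy and 3,5-dimethyl-1,2-oxazol-4-yl. The same entering group measured against 2-methoxyphenyl gives a 1.4-fold higher number from compound 1 to compound 3 (0.14 log units; within the scatter) and so stays unseparated from that six-membered aromatic group, which means that a five-membered aromatic ring with two hetero atoms is accommodated at this place and that the separation holds only against phenoxy. Nothing measured on these compounds speaks to the origin of the step.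

The compounds shown leave open whether the two methyl groups or the ring itself account for the step, a question that the plain 1,2-oxazol-4-yl group would address. They also leave open how this place responds to a non-aromatic terminal group such as morpholine, or to a longer chain carrying an amine.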